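Adding a chloro group to compound 3

This account rests on a few compounds, and the source may have more. Where it says the series, first, only, none or still open, it means among the compounds named here.

In a functional assay on HL-60 cells (Homo sapiens) for antiproliferative activity, read by sulforhodamine B assay, with a stated time of 48 h (on this read-out higher numbers stand for weaker inhibition of growth and lower numbers for stronger inhibition of growth), compound 1 `COc1ccc(S(=O)(=O)c2nc3ccccc3cc2/C=C/C(=O)NO)cc1` gives > 10000 nM, which is a limit of the assay and not a number. Compound 2 `COc1ccc(S(=O)(=O)c2ccc3cc(/C=C/C(=O)NO)ccc3n2)cc1` gives 1140 nM, and compound 3 `O=C(/C=C/c1cccc(S(=O)(=O)c2ccc3ccccc3n2)c1)NO` gives 290 nM. Compound 3 therefore holds the lower of the two actual numbers, and its gap to compound 2 lies beyond the usual scatter of repeated measurements.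

The next molecule, compound 4 `O=C(/C=C/c1cccc(S(=O)(=O)c2ccc3cc(Cl)ccc3n2)c1)NO`, changes compound 3 in one place: chloro in place of hydrogen on an aromatic carbon. In words, a chloro group takes the place of a hydrogen on an aromatic carbon. Going by the values given here, no two measured compounds differ in only one place, so the data offer no direct guide to the size of this change. The best starting point is the parent, compound 3 at 290 nM. The expected step, a 1.3-fold lower number from compound 3 to compound 4 (0.12 log units; within the scatter), is slight, towards stronger inhibition of growth, and stays within the scatter. For compound 4, the estimated value is 220 nM, with an expected range from 70 nM to 700 nM.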

Compound 4, concentration for 50% growth inhibition: 1330 nM
Beside the measured number, compound 4's estimate is 6.0-fold (0.78 log units) below it; the whole stated range lies below it.
By their numbers in this assay, from the lowest: compound 3; then compounds 2 and 4 (each within the scatter of the next). At a limit, above all of these: compound 1.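

Going by these compounds alone, this is the first change that can be read on its own. In this assay, one chloro group in place of a hydrogen gives a 4.6-fold higher number from compound 3 to compound 4 (0.66 log units; beyond the scatter), which means weaker inhibition of growth. This aromatic carbon of the fused two-ring system is therefore sensitive to substitution: a single added chlorine atom moves the number beyond the scatter. Nothing in the data accounts for this drop in activity.

The compounds shown leave open whether the drop is specific to chloro or appears with any group at this carbon, a question that a fluoro, methyl or methoxy group there could help answer. They also leave open whether a chloro group on another carbon of the same ring would give a step of similar size or direction.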